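This account rests on a few compounds, and the source may have more. Where it says the series, first, only, none or still open, it means among the compounds named here.

In a functional assay on K562 cells (Homo sapiens) for cytotoxicity, read by ELISA, with a stated time of 4 days (on this read-out lower numbers stand for stronger inhibition and higher numbers for weaker inhibition), compound 1 (`Cc1ccsc1-c1cc(-c2ccoc2)cc(-c2ccco2)n1`) gives 23300 nM, compound 2 (`Clc1ccc(-c2cc(-c3ccco3)cc(-c3ccc(Cl)s3)n2)cc1`) gives 10500 nM, and compound 3 (`Cc1ccccc1-c1cc(-c2ccoc2)cc(-c2ccc(Cl)s2)n1`) gives 12300 nM. The number for compound 3 thus lies within the scatter of those for both other compounds. Compound 4 (`Clc1cccc(-c2cc(-c3ccoc3)cc(-c3ccc(Cl)s3)n2)c1`) differs from compound 3 by having 3-chlorophenyl in place of 2-methylphenyl on an aromatic carbon, next to the ring nitrogen (3-chlorophenyl in place of 2-methylphenyl on an aromatic carbon). For the measured compounds named here, no measured pair of compounds differs in one place only, so the data offer no direct precedent for this change, and no step beyond the scatter is expected in this assay. The expected step is small: a 1.2-fold lower number from compound 3 to compound 4 (0.09 log units; within the scatter). Compound 4 is estimated at 10000 nM, with an expected range from 4500 nM to 22000 nM.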

Compound 4, half-maximal inhibitory concentration: 22100 nM
Beside the measured number, compound 4's estimate is 2.2-fold (0.34 log units) below it; the whole stated range lies below it.
By their numbers in this assay, from the lowest: compounds 2, 3, 4 and 1 (each within the scatter of the next, the first and the last beyond it).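

In this assay, for the compounds shown here, the exchange of 2-methylphenyl for 3-chlorophenyl on the aromatic carbon next to the ring nitrogen gives a 1.8-fold higher number from compound 3 to compound 4 (0.25 log units; within the scatter) and is the first single-place step at this position. Since that step lies within the scatter, these two aryl groups are not told apart here. No measurement available bears on the result. As far as these compounds go, whether an amine or a carboxylic acid on this carbon would move the number beyond the scatter remains open. So does whether this exchange would give the same step with a group other than furan-3-yl on the core.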